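Shifting the fluorine on compound 1's phenyl ring

The source may report more compounds than this note shows. Statements on the series, on what has been measured and on what is new or still open speak of the compounds shown alone.

Measured compounds:
compound 1 `O=C1C(Nc2ccccc2F)=CC(=O)c2c1nc1n2[C@H]2OC[C@@H](O)[C@H]2OC1` — 2000 nM
compound 2 `O=C1C=C(Nc2ccccc2F)C(=O)c2c1nc1n2[C@H]2OC[C@@H](O)[C@H]2OC1` — 2080 nM
compound 3 `COc1ccc(NC2=CC(=O)c3nc4n(c3C2=O)[C@H]2OC[C@@H](O)[C@H]2OC4)cc1` — 1680 nM

All three measured compounds share one core and differ only in the ring carried on the amine nitrogen or in how that ring sits on the core. In a functional assay on MGC-803 cells (Homo sapiens) for inhibition, read by sulforhodamine B assay (on this read-out higher numbers stand for weaker inhibition and lower numbers for stronger inhibition), the numbers are close together: compound 1 gives 2000 nM, compound 2 gives 2080 nM and compound 3 gives 1680 nM, and no two of them lie further apart than the scatter, so compound 1 cannot be set apart from either neighbour.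

Compound 4 `O=C1C(Nc2cccc(F)c2)=CC(=O)c2c1nc1n2[C@H]2OC[C@@H](O)[C@H]2OC1` differs from compound 1 in one place: 3-fluorophenyl in place of 2-fluorophenyl on an amine nitrogen. Going by the values given here, the only measured step touching that ring is the exchange from compound 2 to compound 3, which gave a 1.2-fold lower number from compound 2 to compound 3 (0.09 log units; within the scatter). Among the compounds with values here, no measured step moves a fluorine within the ring itself. Within the data shown here, since the one related change left the number unmoved, compound 4 is expected to give no change at the digits printed from compound 1 to compound 4 (within the scatter), no step beyond the scatter. The estimate for compound 4 is 2000 nM, with a range from 1000 nM to 4000 nM.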

Compound 4, half-maximal inhibitory concentration: 1470 nM
Estimate against measurement, compound 4: 1.4-fold (0.13 log units) above, and the stated range covers the measured number.
By their numbers in this assay, from the lowest: compounds 4, 3, 1 and 2 (each within the scatter of the next).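

In this assay the exchange of 2-fluorophenyl for 3-fluorophenyl on the amine nitrogen gives a 1.4-fold lower number from compound 1 to compound 4 (0.13 log units; within the scatter), and this is the first step shown that moves the fluorine within the ring itself. Compound 4 and compound 1 have the same atoms joined differently, yet their numbers cannot be told apart, so between these two the place of the fluorine has no effect that can be read beyond the scatter. Nothing available accounts for this result.

On these data alone, whether a chlorine, a carboxylic acid or a longer chain on that ring would give a step beyond the scatter remains open. So does whether 3-fluorophenyl would behave alike with the ring sitting on the core as it does in compound 2.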